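The source may report more compounds than this note shows. Statements on the series, on what has been measured and on what is new or still open speak of the compounds shown alone.

Of the compounds shown here, two sharing one core have been measured so far. Compound 1 `CCCCCN(CCCCC)C(=O)[C@H]1CCN(C(=O)N(c2ccccc2)c2ccccc2)[C@H](C(=O)O)C1` carries a free carboxylic acid on the core, while compound 2 `CCCCCN(CCCCC)C(=O)[C@H]1CCN(C(=O)N(c2ccccc2)c2cccc(Cl)c2)[C@H](C(=O)NCCN(CC(N)=O)C(=O)OCc2ccccc2)C1` has that acid converted into an amide bearing a longer side chain and carries a chlorine on one of the two phenyl rings of the urea. In an assay on CHO cells for binding affinity to Substance-P receptor (Homo sapiens) (on this read-out higher numbers stand for weaker inhibition and lower numbers for stronger inhibition), compound 1 gives 33 nM, and in this assay compound 2 gives 1.8 nM. Of the two numbers, compound 2 has the lower one, and the gap between the two lies beyond the usual scatter, so compound 2 is the stronger inhibitor of this pair. Compound 3 `CCCCCN(CCCCC)C(=O)[C@H]1CCN(C(=O)N(c2ccccc2)c2cccc(Cl)c2)[C@H](C(=O)NCCNCC(N)=O)C1` is the next compound to be measured. It differs from compound 2 in a single place: hydrogen in place of benzyloxycarbonyl on an amine nitrogen. Among the measured compounds shown here, whether removing this group changes the affinity cannot be read from any measured pair here, since no such step has been recorded. The expectation for compound 3 is a modest step towards a weaker inhibitor, a 2.8-fold higher number from compound 2 to compound 3 (0.44 log units; beyond the scatter), which may still lie within the scatter. Compound 3 is thus estimated at 5 nM, with a range from 1.5 nM to 20 nM.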

Compound 3, half-maximal inhibitory concentration: 3.5 nM
Beside the measured number, compound 3's estimate is 1.4-fold (0.15 log units) above it; the measured number falls inside the stated range.
By their numbers in this assay, from the lowest: compounds 2 and 3 (each within the scatter of the next); then compound 1.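

Taking benzyloxycarbonyl off the amine nitrogen and leaving a hydrogen there removes 10 heavy atoms, including a whole six-membered aromatic ring, yet in this assay the result is a 1.9-fold higher number from compound 2 to compound 3 (0.29 log units; within the scatter). The two compounds therefore cannot be told apart on this read-out, which shows that, on this scaffold, the affinity seen with compound 2 does not require benzyloxycarbonyl on this nitrogen, and that the nitrogen can carry either this large group or a simple hydrogen with no difference beyond the scatter. Nothing available here explains why so large a change in structure leaves the number within the scatter.

The compounds shown leave open whether a small group such as methyl or acetyl on the same amine nitrogen would also give a number within the scatter of these two, or whether a group of intermediate size would behave differently. They also leave open how much of the gap to compound 1 comes from the chlorine and how much from the amide side chain, as compound 1 differs from compound 2 and compound 3 in more than one place.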